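The compounds below may be only part of what the source reports. "The series", "measured", "known", "first", "only" and "open" are said of these compounds alone.

Compound 3 `Cc1nc(N[C@H](C)c2ccccc2)nc(N[C@@H]2C[C@H](CO)[C@@H](O)[C@H]2O)c1-c1nc2cnccc2s1` is measured in an ADME assay on cells (Homo sapiens) for cytotoxicity, read by polymerase chain reaction, with a stated time of 3 days (on this read-out lower numbers stand for higher toxicity in this test and higher numbers for lower toxicity in this test), and gives 25000 nM. Its two companions, compound 1 `Cc1nc(N)nc(N[C@@H]2C[C@H](CO)[C@@H](O)[C@H]2O)c1-c1nc2cnccc2s1` with 25000 nM and compound 2 `Cc1nc(NCC2CCN(C)CC2)nc(N[C@@H]2C[C@H](CO)[C@@H](O)[C@H]2O)c1-c1nc2cnccc2s1` with 25000 nM, stand level with it in this assay, so compound 3 occupies neither end of the trio. Compound 4 `Cc1nc(N[C@H](C)c2ccc(-c3cnn(C)c3)cc2)nc(N[C@@H]2C[C@H](CO)[C@@H](O)[C@H]2O)c1-c1nc2cnccc2s1` arises from compound 3 through (1-methyl-1H-pyrazol-4-yl in place of hydrogen on an aromatic carbon). The steps seen so far, no change at the digits printed from compound 1 to compound 3 (within the scatter), no change at the digits printed from compound 2 to compound 3 (within the scatter) and no change at the digits printed from compound 1 to compound 2 (within the scatter), all move nothing beyond the scatter although they swap groups larger than the one now entering. Compound 4 is therefore expected to show a step of no change at the digits printed from compound 3 to compound 4 (within the scatter) in this assay, with no direction beyond the scatter. The estimate for compound 4 is 25000 nM, within a range from 10000 nM to 60000 nM.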

Compound 4, half-maximal cytotoxic concentration: 25000 nM
Beside the measured number, compound 4's estimate shows no gap at the digits printed; low and high end bracket the measured number.
By their numbers in this assay, from the lowest: compounds 1, 2, 3 and 4 (each within the scatter of the next).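

In this assay the new change gives no change at the digits printed from compound 3 to compound 4 (within the scatter). The earlier steps shown here only exchanged the group on the nitrogen, whereas this one places 1-methyl-1H-pyrazol-4-yl on an aromatic carbon of the phenyl ring, and this first substitution on that ring also leaves the read-out unmoved. Nothing available explains this absence of an effect.

On these data alone, whether an amine or a carboxylic acid on that same aromatic carbon would move the number stays open. So does whether any change to the shared core would.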